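Removing the aryl trifluoromethyl group of compound 2

The compounds below may be only part of what the source reports. "The series", "measured", "known", "first", "only" and "open" are said of these compounds alone.

Of the compounds shown here, two carry a number so far. Compound 1 `CC(=O)c1ccc2c(c1)N(C1=CCCC1=O)CC(C)(C)S2` gives 88% in a functional assay on aorta (Rattus norvegicus, strain Wistar); on this read-out lower numbers stand for smaller maximal responses and higher numbers for larger maximal responses. Compound 2 `CC1(C)CN(C2=CCCC2=O)c2cc(C(F)(F)F)ccc2S1` gives 92% in this assay. For the measured compounds named here, the one single-point step measured so far, a number 4 percentage points higher from compound 1 to compound 2 (within the scatter), exchanged one substituent for another at the same aromatic carbon and left the maximal response where it was. Compound 2 thus stands together with compound 1; the two numbers differ by less than the scatter, so neither can be ranked above the other.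

Compound 3 `CC1(C)CN(C2=CCCC2=O)c2ccccc2S1` awaits measurement. Its difference from compound 2 is hydrogen in place of trifluoromethyl on an aromatic carbon. Going by the values given here, the only step that bears on it is a number 4 percentage points higher from compound 1 to compound 2 (within the scatter), which concerns the same position and fell within the scatter. On that basis the step in this assay is expected to be small, with no direction that could be told from the scatter; the expected step is a number 3 percentage points lower from compound 2 to compound 3 (within the scatter). Compound 3 is therefore estimated at 89%, with a range from 74% to 102%.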

Compound 3, largest response reached (Emax), in percent of the reference or control that the assay uses: 90%
For compound 3 the middle estimate is 1 percentage points below the measured one; the range from low to high includes it.
By their numbers in this assay, from the lowest: compounds 1, 3 and 2 (each within the scatter of the next).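

In this assay the unsubstituted position now enters the comparison: the step is a number 2 percentage points lower from compound 2 to compound 3 (within the scatter) and, against the acetyl compound, a number 2 percentage points higher from compound 1 to compound 3 (within the scatter), so hydrogen, trifluoromethyl and acetyl on this aromatic carbon cannot be told apart on maximal response. The earlier step compared only two substituents with each other, whereas these two steps show that, within these three compounds, the maximal response does not need either group at this carbon, since the position left with hydrogen stays within the scatter of both. Nothing measured on these compounds speaks to the reason for this flat outcome.

Whether the position stays this indifferent to other kinds of group, such as an amine, a carboxylic acid or a longer chain, remains open, since the three compounds shown cover only hydrogen, trifluoromethyl and acetyl. From the compounds shown here alone, all three also vary this one aromatic carbon alone, so what a change elsewhere on the shared core does to the maximal response is equally open.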